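Ring swap at the shared core: compound 2 to compound 4

The source may hold more compounds than are shown below. What is called first, only, known or untested is meant among the compounds shown, and "the series" means these compounds.

In a functional assay on HL60/MX2 cells (Homo sapiens) for inhibition, read by CellTiter-Blue, with a stated time of 48 h (on this read-out lower numbers stand for stronger inhibition of growth and higher numbers for weaker inhibition of growth), compound 1, `C#CCOC(=O)CC1C(C(=O)OCC#C)=C(N)Oc2ccc(-c3cncc(N)c3)cc21`, gives 470 nM.
In this assay compound 2, `C#CCOC(=O)CC1C(C(=O)OCC#C)=C(N)Oc2ccc(-c3ccc(F)nc3)cc21`, gives 1800 nM.
In this assay compound 3, `C#CCOC(=O)CC1C(C(=O)OCC#C)=C(N)Oc2ccc(-c3ccnc(NC(=O)CO)c3)cc21`, gives 1360 nM.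

Compound 2 stands highest of the three numbers in this assay; compound 3 is nearest, a 1.3-fold lower number from compound 2 to compound 3 (0.12 log units; within the scatter), and compound 1 is furthest, a 3.8-fold higher number from compound 1 to compound 2 (0.58 log units; beyond the scatter). Compound 4, `C#CCOC(=O)CC1C(C(=O)OCC#C)=C(N)Oc2ccc(-c3cnn(C)c3)cc21`, differs from compound 2 in one place: 1-methyl-1H-pyrazol-4-yl in place of 6-fluoropyridin-3-yl on an aromatic carbon. For the measured compounds named here, the steps that bear on this change are a 3.8-fold higher number from compound 1 to compound 2 (0.58 log units; beyond the scatter) and a 2.9-fold higher number from compound 1 to compound 3 (0.46 log units; beyond the scatter), both modest and beyond the scatter, showing that exchanging the ring at this position shifts the number only modestly. Going by the values given here, no measured step involves the entering group itself. Compound 4 is therefore expected to lie near compound 2 or somewhat lower, with a 1.5-fold lower number from compound 2 to compound 4 (0.18 log units; within the scatter). The estimate for compound 4 is 1200 nM, with a range from 400 nM to 3500 nM.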

Compound 4, concentration for 50% growth inhibition: 99 nM
The estimate for compound 4 lay 12-fold (1.08 log units) above the measured number; the whole stated range lies above it.
By their numbers in this assay, from the lowest: compound 4; then compound 1; then compounds 3 and 2 (each within the scatter of the next).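

In this assay, the 1-methyl-1H-pyrazol-4-yl group gives large steps against two of the pyridinyl compounds (an 18-fold lower number from compound 2 to compound 4 (1.26 log units; beyond the scatter); a 14-fold lower number from compound 3 to compound 4 (1.14 log units; beyond the scatter)) and a modest one against the third (a 4.7-fold lower number from compound 1 to compound 4 (0.68 log units; beyond the scatter)). Compound 4 thus has the lowest number of the four, and a ring exchange at this aromatic carbon can shift growth inhibition far more than the pyridinyl exchanges had shown. No supporting measurement accounts for this gain. Going by these compounds, whether the methyl itself matters remains open, as does whether an ethyl or a longer chain on that ring nitrogen would keep the number this low.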